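Furan swap and amine methylation at the piperidine position

The source may report more compounds than this note shows. Statements on the series, on what has been measured and on what is new or still open speak of the compounds shown alone.

Compound 1 `OC[C@H](NC1CCN(CCCc2c[nH]c3ccc(-n4ccnc4)cc23)CC1)c1ccccc1`: 0.7 nM
Compound 2 `c1cc(CNC2CCN(CCCc3c[nH]c4ccc(-n5cnnc5)cc34)CC2)co1`: 4.5 nM
Compound 3 `CC(=O)Nc1ccc(CNC2CCN(CCCc3c[nH]c4ccc(-n5cnnc5)cc34)CC2)cc1`: 3 nM

In an assay on CHO cells for displacement of a labelled ligand from 5-hydroxytryptamine receptor 1D (Homo sapiens) (on this read-out higher numbers stand for weaker inhibition and lower numbers for stronger inhibition), compound 2 gives 4.5 nM, the highest of the three numbers; compound 3 sits nearest, a 1.5-fold lower number from compound 2 to compound 3 (0.18 log units; within the scatter), while compound 1 lies furthest, beyond the scatter. Compound 4 `CN(Cc1ccco1)C1CCN(CCCc2c[nH]c3ccc(-n4cnnc4)cc23)CC1` differs from compound 2 by ((furan-2-yl)methyl)(methyl)amino in place of ((furan-3-yl)methyl)amino on a saturated ring carbon. For the measured compounds named here, no measured step covers this change directly; the only step at this position, a 1.5-fold lower number from compound 2 to compound 3 (0.18 log units; within the scatter), exchanged the aryl group alone and stayed within the scatter. With no comparison for the added methyl on the amine nitrogen, the expectation is a small step, a 1.3-fold higher number from compound 2 to compound 4 (0.12 log units; within the scatter), most likely within the scatter. Compound 4 is therefore expected to give about 6 nM, with a range from 2 nM to 18 nM.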

Compound 4, half-maximal inhibitory concentration: 9.3 nM
Compound 4: the middle estimate sits 1.6-fold (0.19 log units) below what was measured; the range from low to high includes it.
By their numbers in this assay, from the lowest: compound 1; then compounds 3 and 2 (each within the scatter of the next); then compound 4.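

At this position, the change gives a 2.1-fold higher number from compound 2 to compound 4 (0.32 log units; beyond the scatter) in this assay and, unlike the aryl exchange alone, goes beyond the scatter. It moves the furan attachment from furan-3-yl to furan-2-yl and adds a methyl on the amine nitrogen, leaving the group without a hydrogen-bond donor, so the step belongs to these changes together. Nothing available explains the step.

Which of the two changes carries the step stays open. So does how an ethyl or acetyl group on that amine nitrogen would read.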